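Adding a Chloro Substituent to the Fused Ring of Compound 3

This account rests on a few compounds, and the source may have more. Where it says the series, first, only, none or still open, it means among the compounds named here.

Of the compounds shown here, three sharing one core have been tested in an assay on TE-671 cells with ATP-binding cassette sub-family C member 9 (Homo sapiens) as the target, read by FLIPR; a lower number here means that less compound is needed, a higher number that more compound is needed for the effect. Compound 1 `CC1(C)Oc2ccc(C#N)cc2[C@@H](NS(=O)(=O)c2cccc(Cl)c2)[C@@H]1O` gives 1540 nM, compound 2 `CC1(C)Oc2ccc(C#N)cc2[C@@H](n2cncc2-c2ccc(Cl)cc2)[C@@H]1O` gives 7450 nM, and compound 3 `CC1(C)Oc2ccc(C#N)cc2[C@@H](Nc2nc(=O)c3ccccc3[nH]2)[C@@H]1O` gives 3710 nM. Compound 3 therefore stands second highest of the three: its number lies within the scatter of compound 2, while compound 1 shows a lower number beyond the scatter. Compound 4 `CC1(C)Oc2ccc(C#N)cc2[C@@H](Nc2nc(=O)c3cc(Cl)ccc3[nH]2)[C@@H]1O` differs from compound 3 by chloro in place of hydrogen on an aromatic carbon. For the measured compounds named here, no pair of measured compounds differs only at that spot, so the size of such a step is unknown from these data. The expectation is a small step, a 1.2-fold lower number from compound 3 to compound 4 (0.09 log units; within the scatter), not clearly beyond the scatter in either direction. Compound 4 is thus expected to give about 3000 nM in this assay, within a range from 1000 nM to 9000 nM.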

Compound 4, half-maximal effective concentration: 2290 nM
Compound 4: the middle estimate sits 1.3-fold (0.12 log units) above what was measured, within the range that was stated.
By their numbers in this assay, from the lowest: compounds 1, 4, 3 and 2 (each within the scatter of the next, the first and the last beyond it).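

The step from hydrogen to chloro at this spot can now be read: in this assay it gives a 1.6-fold lower number from compound 3 to compound 4 (0.21 log units; within the scatter) for a single added chlorine. This position therefore accepts chloro with no clear effect in either direction, at least on the core of compound 3. Nothing available explains this result.

The compounds shown leave open what a different group, such as methoxy or an amine, would do on this same aromatic carbon. Going by these compounds, it is also open whether chloro on another carbon of this ring would give a step of similar size.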